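The source may report more compounds than this note shows. Statements on the series, on what has been measured and on what is new or still open speak of the compounds shown alone.

Compound 1 `Nc1ccc(S(=O)(=O)N2CCN(c3ncc(C(O)(C(F)(F)F)C(F)(F)F)cc3C#CCCO)CC2)cn1`: 68 mL.min-1.g-1
Compound 2 `Cn1cc(-c2cc(C(O)(C(F)(F)F)C(F)(F)F)cnc2N2CCN(S(=O)(=O)c3ccc(N)nc3)CC2)cn1`: 44 mL.min-1.g-1
Compound 3 `CC(C)n1cc(-c2cc(C(O)(C(F)(F)F)C(F)(F)F)cnc2N2CCN(S(=O)(=O)c3ccc(N)nc3)CC2)cn1`: 198 mL.min-1.g-1

In an ADME assay (liver) for metabolic stability, with Liver microsome (Rattus norvegicus) as the target, using microsomes and NADPH, with a stated time of 30 min, tested at 1 uM (a lower number here means slower removal, a higher number faster removal of the compound), compound 2 is separated from compound 1 by a 1.5-fold lower number from compound 1 to compound 2 (0.19 log units; within the scatter) and from compound 3 by a 4.5-fold higher number from compound 2 to compound 3 (0.65 log units; beyond the scatter). Compound 4 `Nc1ccc(S(=O)(=O)N2CCN(c3ncc(C(O)(C(F)(F)F)C(F)(F)F)cc3-c3ccc4scnc4c3)CC2)cn1` differs from compound 2 as follows.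

1,3-benzothiazol-5-yl in place of 1-methyl-1H-pyrazol-4-yl on an aromatic carbon

For the measured compounds named here, no measured step exchanges one aromatic ring for another on this aromatic carbon, so the guides are the changes made there: a 2.9-fold higher number from compound 1 to compound 3 (0.46 log units; beyond the scatter) and a 4.5-fold higher number from compound 2 to compound 3 (0.65 log units; beyond the scatter), both of which raised the number, while a 1.5-fold lower number from compound 1 to compound 2 (0.19 log units; within the scatter) stayed within the scatter. A modest rise in this assay is therefore expected for compound 4, with real uncertainty about its size. Compound 4 is estimated at 110 mL.min-1.g-1, within a range of 45 mL.min-1.g-1 to 270 mL.min-1.g-1. That estimate is expected to amount to a 2.5-fold higher number from compound 2 to compound 4 (0.40 log units; beyond the scatter).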

Compound 4, intrinsic clearance in microsomes: 147 mL.min-1.g-1
Beside the measured number, compound 4's estimate is 1.3-fold (0.13 log units) below it; measured number inside the range.
By their numbers in this assay, from the lowest: compounds 2 and 1 (each within the scatter of the next); then compounds 4 and 3 (each within the scatter of the next).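

In this assay, the 1,3-benzothiazol-5-yl group shows that a fused aromatic group on this aromatic carbon gives a 3.3-fold higher number from compound 2 to compound 4 (0.52 log units; beyond the scatter) and a 2.2-fold higher number from compound 1 to compound 4 (0.33 log units; beyond the scatter) while a 1.3-fold lower number from compound 3 to compound 4 (0.13 log units; within the scatter) stays within the scatter. The high end of the series is therefore reached not only with the isopropyl on the pyrazole but also with a quite different ring system.

From the compounds shown here alone, whether an amine or a carboxylic acid on this carbon would stay nearer compound 2 or compound 4 remains open. No evidence is available to explain these differences.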